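The source may hold more compounds than are shown below. What is called first, only, known or untested is meant among the compounds shown, and "the series" means these compounds.

Working notes on the series.

Two compounds have numbers in an assay on CHO cells for inhibition of sodium- and chloride-dependent glycine transporter 1 (Homo sapiens), read by scintillation counting (a higher number here means that more compound is needed for the effect, a lower number that less compound is needed), so far. Compound 1 `C[C@H](Oc1ccc(S(C)(=O)=O)cc1C(=O)N1Cc2ccccc2C1)C(F)(F)F` gives 2540 nM in this assay. Compound 2 `C[C@H](Oc1ccc(S(C)(=O)=O)cc1C(=O)N1Cc2cc(C(F)(F)F)cnc2C1)C(F)(F)F` gives 50 nM in this assay and stands at the lowest of the two numbers; the gap to compound 1 is beyond the scatter. The two compounds differ in more than one place, so no single step can be read from them, and only the two values themselves are to be taken.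

Compound 3 `CS(=O)(=O)c1ccc(OCc2ccccc2)c(C(=O)N2Cc3cc(C(F)(F)F)cnc3C2)c1` has not yet been measured in this assay. It differs from compound 2 in one place: benzyl in place of 1-(trifluoromethyl)ethyl on an oxygen on an aromatic ring. Among the compounds with values here, no measured step of this kind exists, so the size of the change is open. The expectation is a moderate step upward in this assay, a 4.0-fold higher number from compound 2 to compound 3 (0.60 log units; beyond the scatter) from compound 2 to compound 3, beyond the scatter but well short of the gap that separates compound 1 from compound 2. For compound 3 the estimated value in this assay is 200 nM, with a range from 60 nM to 700 nM.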

Compound 3, half-maximal effective concentration: 805 nM
Beside the measured number, compound 3's estimate is 4.0-fold (0.60 log units) below it, and the stated range ends below it.
By their numbers in this assay, from the lowest: compound 2; then compound 3; then compound 1.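

Within the data shown here, the change from 1-(trifluoromethyl)ethyl to benzyl on an oxygen on an aromatic ring gives, in this assay, a 16-fold higher number from compound 2 to compound 3 (1.21 log units; beyond the scatter) and is the first single-place step that can be read. It shows that this position is sensitive to the group it carries: with the rest of compound 2 unchanged, going from 1-(trifluoromethyl)ethoxy to benzyloxy alone means that much more compound is needed for the effect. The change removes a defined stereocentre and three fluorine atoms and brings in a six-membered aromatic ring of carbon only, but no measurement at hand ties the step to any one of these differences.

Still open, on these data alone, is which of these differences carries the step, and a trifluoroethyl or a cyclopropylmethyl group on the same oxygen would help to separate them. Also open, as far as these compounds go, are the opposite stereocentre of the 1-(trifluoromethyl)ethyl group and whether a fluorine or a methoxy group on the benzyl ring would move the number in either direction.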